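This account rests on a few compounds, and the source may have more. Where it says the series, first, only, none or still open, it means among the compounds named here.

Working notes on the series. Three compounds of the shared core have been run in an in vitro functional assay on CHO-CREluc cells for antagonist activity at growth hormone secretagogue receptor type 1 (Homo sapiens), read by a luciferase reporter, with a stated time of 4 h; on this read-out lower numbers stand for stronger inhibition and higher numbers for weaker inhibition. Compound 3 `CCN1CCCC(CC(=O)NC2(c3ccc(Cl)c(Cl)c3)C(=O)Nc3cc(Cl)cc(Cl)c32)C1` gives 47 nM, the lowest of the three numbers. Compound 1 `CCN1CCN(CC(=O)NC2(c3ccc(Cl)c(Cl)c3)C(=O)Nc3cc(Cl)cc(Cl)c32)CC1=O` gives 2780 nM in this assay. Compound 2 `CN1CCN(CC(=O)NC2(c3ccc(C(C)(C)C)cc3)C(=O)Nc3cc(Cl)c(Cl)cc32)CC1` differs from compound 3 in several places, and in this assay compound 2 gives 1470 nM. Among the compounds with values here, the only single-point step between measured compounds is a 59-fold lower number from compound 1 to compound 3 (1.77 log units; beyond the scatter), a large move on the saturated chain carbon bound to a carbonyl carbon.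

The next compound is compound 4 `CN1CCCN(CC(=O)NC2(c3ccc(Cl)c(Cl)c3)C(=O)Nc3cc(Cl)cc(Cl)c32)CC1`; the change from compound 3 is 4-methyl-1,4-diazepan-1-yl in place of 1-ethylpiperidin-3-yl on a saturated chain carbon bound to a carbonyl carbon. This change runs partly back toward compound 1: the ring is again attached through a nitrogen and again holds two hetero atoms, yet the oxo group of compound 1 is not present and a methyl replaces the ethyl on the second nitrogen. Within the data shown here, only the step between compound 1 and compound 3 bears on it, and it points to a higher number for compound 4 than for compound 3, short of compound 1, because a 59-fold lower number from compound 1 to compound 3 (1.77 log units; beyond the scatter) combined the loss of the oxo group with the change of attachment, of which compound 4 reverses only the attachment. The expected step is a 3.4-fold higher number from compound 3 to compound 4 (0.53 log units; beyond the scatter). Compound 4 is therefore estimated at 160 nM in this assay, within a range from 40 nM to 650 nM.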

Compound 4, half-maximal inhibitory concentration: 64 nM
The estimate for compound 4 lay 2.5-fold (0.40 log units) above the measured number; the range from low to high includes it.
By their numbers in this assay, from the lowest: compounds 3 and 4 (each within the scatter of the next); then compounds 2 and 1 (each within the scatter of the next).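

In this assay the exchange of 1-ethylpiperidin-3-yl for 4-methyl-1,4-diazepan-1-yl gives a 1.4-fold higher number from compound 3 to compound 4 (0.13 log units; within the scatter) and so, on this saturated chain carbon bound to a carbonyl carbon, a seven-membered ring with two nitrogens attached through nitrogen reads the same as the six-membered ring with one nitrogen attached through carbon. Set against the earlier step alone, a 43-fold lower number from compound 1 to compound 4 (1.64 log units; beyond the scatter) shows that attachment through a ring nitrogen does not by itself bring the high number of compound 1, although this step changes ring size, the oxo group and the alkyl group on nitrogen together and cannot be divided among them. No measurement on hand accounts for either step.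

The compounds shown leave open which of those three differences carries the large step, a question that 4-ethylpiperazin-1-yl and 4-ethyl-1,4-diazepan-1-yl on the same core would help to separate. As far as these compounds go, it also remains open how far this position accepts a group without a ring, such as an open-chain dimethylamino group or a carboxylic acid.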